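The source may hold more compounds than are shown below. What is called first, only, known or untested is meant among the compounds shown, and "the series" means these compounds.

Of the compounds shown here, two have so far been measured in an assay on microsomes from brain (strain Sprague-Dawley) for inhibition of heme oxygenase 2 (Rattus norvegicus), read by spectrophotometry, with a stated time of 60 min; on this read-out higher numbers stand for weaker inhibition and lower numbers for stronger inhibition. Compound 1 `c1ccc2sc(SCCCCn3ccnc3)nc2c1` gives 800 nM in this assay, while compound 2 `O=[N+]([O-])c1ccc(OCCCn2cncn2)cc1` gives 44700 nM, the higher of the two numbers and therefore the weaker inhibition of the pair; the two cores differ in more than one place, so only the two values themselves can be compared. Compound 3 `O=[N+]([O-])c1ccc(OCCCn2ccnc2)cc1` has not yet been measured. It differs from compound 2 in a single way: 1H-imidazol-1-yl in place of 1H-1,2,4-triazol-1-yl on a saturated chain carbon, three bonds along the chain from an oxygen on an aromatic ring. This is the same five-membered ring found at the chain end of compound 1. Within the data shown here, no measured pair shows this ring swap on its own. The expected step in this assay from compound 2 to compound 3 is a 7.5-fold lower number from compound 2 to compound 3 (0.87 log units; beyond the scatter), a drop in the number beyond the usual scatter. Compound 3 is estimated at 6000 nM, in a range from 1500 nM to 25000 nM.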

Compound 3, half-maximal inhibitory concentration: 77600 nM
Compound 3: the middle estimate sits 13-fold (1.11 log units) below what was measured; the measured number lies above the stated range.
By their numbers in this assay, from the lowest: compound 1; then compounds 2 and 3 (each within the scatter of the next).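

Among these compounds, this is the first pair that isolates the ring swap: in this assay, 1H-imidazol-1-yl in place of 1H-1,2,4-triazol-1-yl on a saturated chain carbon, three bonds along the chain from an oxygen on an aromatic ring, gives a 1.7-fold higher number from compound 2 to compound 3 (0.24 log units; within the scatter). That step lies within the usual scatter of repeated measurements, so the two rings cannot be told apart at this position on this core. Nothing available accounts for this result.

Going by these compounds, it remains open whether the same swap would also stay within the scatter on the core of compound 1. On these data alone, it is also open whether replacing the ring at this chain end with a primary amine or a carboxylic acid would shift the number beyond the scatter.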